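This account rests on a few compounds, and the source may have more. Where it says the series, first, only, none or still open, it means among the compounds named here.

For the measured compounds named here, compound 3 `CCCCCc1ccc(C#Cc2cn(C/C=C/CN3C(=O)c4ccccc4C3=O)c(=O)[nH]c2=O)cc1` gives 25000 nM in an ADME assay on WI-38 cells (Homo sapiens) for cytotoxicity, read by MTT assay, with a stated time of 3 days (on this read-out higher numbers stand for weaker inhibition and lower numbers for stronger inhibition), the lowest of the three numbers measured so far. Compound 1 `CCCCCCC#Cc1cn(C/C=C/CN2C(=O)c3ccccc3C2=O)c(=O)[nH]c1=O` gives 40000 nM in this assay, and compound 2 `CCCCCCCCC#Cc1cn(C/C=C/CN2C(=O)c3ccccc3C2=O)c(=O)[nH]c1=O` gives 53000 nM. The step of a 1.6-fold lower number from compound 1 to compound 3 (0.20 log units; within the scatter) lies within the scatter, while the step of a 2.1-fold lower number from compound 2 to compound 3 (0.33 log units; beyond the scatter) is modest but beyond it. Compound 4 `CCCCc1ccc(C#Cc2cn(C/C=C/CN3C(=O)c4ccccc4C3=O)c(=O)[nH]c2=O)cc1` differs from compound 3 by hydrogen in place of methyl on a saturated chain carbon, four bonds along the chain from an aromatic carbon. Going by the values given here, the only measured step that bears on a change of chain length is a 1.3-fold higher number from compound 1 to compound 2 (0.12 log units; within the scatter), and it stayed within the scatter. Compound 4 is therefore expected to show no step beyond the scatter, no change at the digits printed from compound 3 to compound 4 (within the scatter). Compound 4 is estimated to give 25000 nM in this assay, with a range from 12000 nM to 50000 nM.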

Compound 4, half-maximal inhibitory concentration: 40000 nM
Estimate against measurement, compound 4: 1.6-fold (0.20 log units) below; low and high end bracket the measured number.
By their numbers in this assay, from the lowest: compounds 3, 1, 4 and 2 (each within the scatter of the next, the first and the last beyond it).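

Hydrogen in place of methyl at this place gives a 1.6-fold higher number from compound 3 to compound 4 (0.20 log units; within the scatter) and so shows that shortening the chain on the phenyl group by this one carbon moves the number in this assay by no more than the scatter. Against the plain chains, 4-butylphenyl gives no change at the digits printed from compound 1 to compound 4 (within the scatter) and a 1.3-fold lower number from compound 2 to compound 4 (0.12 log units; within the scatter) and so does not stand apart from either, although a 2.1-fold lower number from compound 2 to compound 3 (0.33 log units; beyond the scatter) lay beyond the scatter. No measurement shown gives a cause for these numbers.

From the compounds shown here alone, whether a propyl chain, an amine or a carboxylic acid in place of the butyl group would move the number beyond the scatter stays open.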